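Bromo for fluoro on the benzyl of compound 2

The source may report more compounds than this note shows. Statements on the series, on what has been measured and on what is new or still open speak of the compounds shown alone.

Compound 1 `CCCSc1nc(N/N=C(\C)c2ccccc2O)c2nnn(Cc3ccccc3Cl)c2n1` reaches only the limit > 64000 nM in a functional assay on ECa-109 cells (Homo sapiens) for antiproliferative activity, read by MTT assay, with a stated time of 72 h; a lower number here means a stronger inhibitor, a higher number a weaker inhibitor. Compound 3 `CCCSc1nc(N/N=C/c2ccc(Br)cc2)c2nnn(Cc3ccccc3)c2n1` likewise stops at the limit > 64000 nM. Among the compounds with values here, compound 2 `CCCSc1nc(N/N=C(\C)c2ccccc2O)c2nnn(Cc3ccc(F)cc3)c2n1` gives 21900 nM in this assay, the only measured number among the three. Two of the three values sit at the limit of > 64000 nM in this assay, at which 2 of the 3 values shown sit. Within the data shown here, the single one-change step recorded is an at least 2.9-fold lower number from compound 1 to compound 2 (0.46 log units; beyond the scatter), 4-fluorophenyl in place of 2-chlorophenyl on a saturated chain carbon bound to an aromatic nitrogen. Compound 4 `CCCSc1nc(N/N=C(\C)c2ccccc2O)c2nnn(Cc3ccc(Br)cc3)c2n1` differs from compound 2 by bromo in place of fluoro on an aromatic carbon. The recorded step bears on this only loosely: it swapped both the halogen and where it sits on the ring, whereas here only the halogen changes and its ring position stays. Compound 3 differs from compound 2 in more than one place and offers no one-change comparison. A step of a 1.1-fold lower number from compound 2 to compound 4 (0.04 log units; within the scatter) is therefore expected, within the scatter. Compound 4 is estimated at 20000 nM in this assay, with a range of 7000 nM to 60000 nM.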

Compound 4, half-maximal inhibitory concentration: 36100 nM
The estimate for compound 4 lay 1.8-fold (0.26 log units) below the measured number; low and high end bracket the measured number.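

In this assay, bromo in place of fluoro on an aromatic carbon para to a large group gives a 1.6-fold higher number from compound 2 to compound 4 (0.22 log units; within the scatter), so with the ring place held fixed, this halogen swap does not separate the two compounds. Replacing 2-chlorophenyl with 4-bromophenyl gives an at least 1.7-fold lower number from compound 1 to compound 4 (0.24 log units; that floor lies within the scatter), a floor resting on a limit that does not by itself establish a difference: the limit of > 64000 nM in this assay, at which 2 of the 4 values shown sit. Within the data shown here, the earlier step from 2-chlorophenyl to 4-fluorophenyl remains the only step here that lies beyond the scatter.

A 4-chlorophenyl group in this place would be needed to separate the identity of the halogen from its ring place. Going by these compounds, how a 4-methoxyphenyl or 4-aminophenyl group would read against compound 2 also remains open.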